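Testing an Oxadiazole in Place of an Amide

This account rests on a few compounds, and the source may have more. Where it says the series, first, only, none or still open, it means among the compounds named here.

Compound 1 `CC(C)[C@H]1C(O)=C(C2=NS(=O)(=O)c3ccccc32)C(=O)N1Cc1ccccc1` sits at the edge of what an ADME assay on Huh-7 cells (Homo sapiens) for cytotoxicity, with a stated time of 72 h (a higher number here means that more compound is tolerated, a lower number that less compound is tolerated), can read: compound 1 gives > 33000 nM, which is a limit of the assay rather than a number. Compound 2 `CC(C)[C@H]1C(O)=C(C2=NS(=O)(=O)c3c(OCC(N)=O)cccc32)C(=O)N1Cc1ccccc1` likewise gives > 33000 nM in this assay, again only a limit. The step that the two limits leave unreadable from compound 1 to compound 2 cannot be sized, since (the limit of > 33000 nM in this assay, at which 2 of the 2 values shown sit). Compound 3 `CC(C)[C@H]1C(O)=C(C2=NS(=O)(=O)c3c(OCc4ncon4)cccc32)C(=O)N1Cc1ccccc1` differs from compound 2 by 1,2,4-oxadiazol-3-yl in place of carbamoyl on a saturated chain carbon bound to an oxygen on an aromatic ring. Among the measured compounds shown here, no measured step bears directly on this change, and both known values are limits. The expected step that the limit leaves unreadable from compound 2 to compound 3 is therefore none beyond the usual scatter. Compound 3 is estimated at 40000 nM, with a range from 15000 nM to 100000 nM.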

Compound 3, half-maximal cytotoxic concentration: > 33000 nM
Compound 3: a limit, no number; the forecaster's own chance of this, stated with the estimate: 80%; the middle value does not contradict the limit.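

Compound 3 also gives only a limit, so no step can be read among compound 1, compound 2 and compound 3: the limit of > 33000 nM in this assay, at which 3 of the 3 values shown sit.

From the compounds shown here alone, whether either added group changes how much compound is tolerated in this assay stays open.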